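Replacing a methoxy with methylamino on the carbonyl

This account rests on a few compounds, and the source may have more. Where it says the series, first, only, none or still open, it means among the compounds named here.

Of the compounds shown here, two have been tested in a functional assay on HUVEC cells (Homo sapiens), read by MTT assay, with a stated time of 72 h; a higher number here means that more compound is needed for the effect, a lower number that less compound is needed. Compound 1, with the structure `COC(=O)c1cc2cc(NCc3cc(NC(=O)c4cncc(C)c4)ccc3C)cnc2[nH]1`, reached only the limit of the assay, giving > 1000 nM, which is a limit rather than a number, as noted by the limit of > 1000 nM in this assay, at which 1 of the 2 values shown sits. For the measured compounds named here, compound 2, with the structure `COC(=O)c1cc2cc(NCc3cc(NC(=O)c4ccc(CN5CCC(N(C)C)C5)c(C(F)(F)F)c4)ccc3C)cnc2[nH]1`, gives 689 nM in this assay, and this is the only numerical value in the set, so there is no comparison within the scatter to place it against.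

Compound 3, with the structure `CNC(=O)c1cc2cc(NCc3cc(NC(=O)c4ccc(CN5CCC(N(C)C)C5)c(C(F)(F)F)c4)ccc3C)cnc2[nH]1`, differs from compound 2 in one place: methylamino in place of methoxy on a carbonyl carbon, or methoxycarbonyl to methylcarbamoyl. Going by the values given here, no measured pair shows the effect of this change, so no direction can be read from the data. The step from compound 2 to compound 3 is expected to stay within the scatter, at a 1.1-fold lower number from compound 2 to compound 3 (0.06 log units; within the scatter). Compound 3 is therefore estimated at 600 nM, with a range from 250 nM to 1500 nM.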

Compound 3, half-maximal effective concentration: 83 nM
The estimate for compound 3 lay 7.2-fold (0.86 log units) above the measured number, outside the stated range (below it).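

On this carbonyl carbon, whose other neighbour is an aromatic carbon, putting methylamino in place of methoxy gives in this assay an 8.3-fold lower number from compound 2 to compound 3 (0.92 log units; beyond the scatter). For the compounds shown here, the earlier compounds offered no pair differing in one place, so this is the first direct reading of the position, and it shows that methoxycarbonyl to methylcarbamoyl is far from a silent exchange, even though the two end groups have the same count of heavy atoms. Nothing measured among these compounds explains the lower number.

Going by these compounds, this is a single pair on a single background, so it remains open whether the same change would lower the number on the background of compound 1. On these data alone, it also remains open how specific the effect is to methylamino, since a plain amino group, a dimethylamino group or a carboxylic acid at this carbonyl would be needed to tell.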